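Methyl Replaces an Acyl Group on the Ring Nitrogen

This account rests on a few compounds, and the source may have more. Where it says the series, first, only, none or still open, it means among the compounds named here.

In a physicochemical assay for solubility (on this read-out higher numbers stand for higher solubility and lower numbers for lower solubility), compound 1 `CC(C)(C)C(=O)N1CCC[C@H]1C(=O)N1CCC(NS(=O)(=O)c2cc(S(=O)(=O)c3ccccc3)ccc2C(F)(F)F)CC1` gives 50000 nM and compound 2 `O=C([C@@H]1CCCN1C(=O)c1ccncc1)N1CCC(NS(=O)(=O)c2cc(S(=O)(=O)c3ccccc3)ccc2C(F)(F)F)CC1` gives 100000 nM on the same read-out. These two numbers lie within the scatter of each other, so the data do not separate compound 2 from compound 1. Compound 3 `CN1CCC[C@H]1C(=O)N1CCC(NS(=O)(=O)c2cc(S(=O)(=O)c3ccccc3)ccc2C(F)(F)F)CC1` has not yet been measured in this assay and carries methyl in place of (pyridin-4-yl)carbonyl on an amine nitrogen in a ring. Within the data shown here, one measured step bears on this change, namely a 2.0-fold higher number from compound 1 to compound 2 (0.30 log units; within the scatter) for pyridin-4-yl in place of tert-butyl on a carbonyl carbon. It is only a weak guide, since compound 1 and compound 2 both keep a carbonyl on that nitrogen and compound 3 has none there. Among the measured compounds shown here, no measured compound carries methyl at this place. Taking compound 2 at 100000 nM as the starting point, no step beyond the scatter is expected in this assay and the data give no direction. The expected step is a 1.1-fold lower number from compound 2 to compound 3 (0.05 log units; within the scatter) in this estimate. Compound 3 is estimated at 90000 nM with a range from 35000 nM to 230000 nM as the expected bounds.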

Compound 3, solubility: 100000 nM
Estimate against measurement, compound 3: 1.1-fold (0.05 log units) below; the measured number falls inside the stated range.
By their numbers in this assay, from the lowest: compounds 1, 2 and 3 (each within the scatter of the next).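

In this assay the amine nitrogen in a ring now carries methyl and no carbonyl at all, and neither acyl group is separated from it (for methyl in place of (pyridin-4-yl)carbonyl, no change at the digits printed from compound 2 to compound 3 (within the scatter); for methyl in place of (tert-butyl)carbonyl, a 2.0-fold higher number from compound 1 to compound 3 (0.30 log units; within the scatter)). The earlier pair kept a carbonyl on this nitrogen in both compounds, so only now does the read-out cover this place with the carbonyl gone, and all three compounds stand within the scatter of one another, whether a small alkyl group or either of two quite different acyl groups sits there. Nothing measured alongside these numbers offers an account of this result.

The compounds shown leave open whether any other group on this nitrogen would give a step beyond the scatter, for instance a bare hydrogen, a longer alkyl chain or a chain ending in a carboxylic acid. They also leave open whether the same holds once the shared core is altered elsewhere, since all three compounds keep it unchanged.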